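Moving the amide substituent from methyl to fluorine

The source may report more compounds than this note shows. Statements on the series, on what has been measured and on what is new or still open speak of the compounds shown alone.

Compound 1 `COc1cc(-c2cc(C(=O)O)c3ccccc3n2)ccc1OCC(=O)Nc1ccccc1C` and compound 2 `COc1cc(-c2cc(C(=O)O)c3ccccc3n2)ccc1OCC(=O)Nc1cccc(C)c1` share one core and differ only in the group on the amide nitrogen. In a physicochemical assay for lipophilicity, using the shake flask method, in phosphate buffer, measured as octanol-water partition, at pH 7.4 (a higher number here means a more lipophilic compound, a lower number a more polar compound), compound 1 gives 0.8, the lowest of the two numbers, while compound 2 gives 1.5; the change a number 0.70 log units higher from compound 1 to compound 2 (beyond the scatter). Compound 3 `COc1cc(-c2cc(C(=O)O)c3ccccc3n2)ccc1OCC(=O)Nc1cccc(F)c1` carries a different change on the same nitrogen: 3-fluorophenyl in place of 2-methylphenyl on an amide-type nitrogen. Among the measured compounds shown here, only the step from compound 1 to compound 2 bears on this, and it shares just the move of the substituent; fluorine is not methyl. The expected step is an upward one of a number 0.40 log units higher from compound 1 to compound 3 (beyond the scatter), smaller than that one. Compound 3 is therefore estimated at 1.2, within an expected range of 0.7 to 1.7.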

Compound 3, distribution coefficient: 1.6
For compound 3 the middle estimate is 0.40 log units below the measured one; the measured number falls inside the stated range.
By their numbers in this assay, from the lowest: compound 1; then compounds 2 and 3 (each within the scatter of the next).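

Replacing 2-methylphenyl with 3-fluorophenyl on the amide-type nitrogen gives a number 0.80 log units higher from compound 1 to compound 3 (beyond the scatter) in this assay, so the upward step seen with compound 2 also appears with a fluoro group. Fluoro in place of methyl on the aromatic carbon gives a number 0.10 log units higher from compound 2 to compound 3 (within the scatter), so this pair offers no reading of a difference between the two groups. Nothing available here explains these numbers. Still open, on these data alone, is whether a larger change on that aromatic carbon, such as an amine or a nitrile, would keep the number in this range.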